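The source may hold more compounds than are shown below. What is called first, only, known or untested is meant among the compounds shown, and "the series" means these compounds.

In a functional assay on HL-60 cells (Homo sapiens) for antiproliferative activity, read by MTT assay, with a stated time of 72 h (a lower number here means a stronger inhibitor, a higher number a weaker inhibitor), compound 1 `CC(=O)N(C)c1ccc2[nH]c(-c3n[nH]c4ccccc34)cc2n1` gives 5110 nM, compound 2 `CN(C(=O)c1ccco1)c1ccc2[nH]c(-c3n[nH]c4ccccc34)cc2n1` gives 4540 nM, and compound 3 `Cc1ccc(S(=O)(=O)N(C)c2ccc3[nH]c(-c4n[nH]c5ccccc45)cc3n2)cc1` gives 3030 nM. Compound 3 carries the lowest of the three numbers shown, yet its separation from compound 2 is a step of a 1.5-fold lower number from compound 2 to compound 3 (0.18 log units; within the scatter) and from compound 1 a step of a 1.7-fold lower number from compound 1 to compound 3 (0.23 log units; within the scatter), both inside the scatter, so the three compounds cannot be ranked against one another.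

Compound 4 `CN(c1ccc2[nH]c(-c3n[nH]c4ccccc34)cc2n1)S(=O)(=O)c1ccc(Br)cc1` differs from compound 3 by bromo in place of methyl on an aromatic carbon. Among the compounds with values here, no measured step touches this ring position: the steps seen so far exchange the whole group on the nitrogen, including a 1.1-fold lower number from compound 1 to compound 2 (0.05 log units; within the scatter), and every one of them stays within the scatter. Since exchanges of the entire group on the nitrogen left the numbers unmoved, the smaller swap of methyl for bromo on the outer ring is expected to give a step of a 1.0-fold lower number from compound 3 to compound 4 (0.00 log units; within the scatter), that is, none beyond the scatter. Compound 4 is therefore estimated at 3000 nM, with a range from 1200 nM to 7500 nM.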

Compound 4, half-maximal inhibitory concentration: 6240 nM
Compound 4: the middle estimate sits 2.1-fold (0.32 log units) below what was measured; the measured number falls inside the stated range.
By their numbers in this assay, from the lowest: compounds 3, 2, 1 and 4 (each within the scatter of the next, the first and the last beyond it).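

Within the data shown here, with this assay as the read-out, the outer ring of the sulfonyl group gives the only single change so far that reaches beyond the scatter: bromo in place of methyl, on an aromatic carbon para to a large group, is a 2.1-fold higher number from compound 3 to compound 4 (0.31 log units; beyond the scatter), a modest step. Exchanges of the whole group on the nitrogen still do not separate the compounds, as a 1.4-fold higher number from compound 2 to compound 4 (0.14 log units; within the scatter) and a 1.2-fold higher number from compound 1 to compound 4 (0.09 log units; within the scatter) both stay within the scatter, so this ring position is sensitive only in the comparison of bromo with methyl. Nothing available explains why this swap moves the number.

The compounds shown leave open how a bare hydrogen, a chloro, a methoxy or an amine would read at this ring carbon. They also leave open whether the same swap would give a similar step with the bromo or methyl moved to another carbon of the ring.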